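The source may hold more compounds than are shown below. What is called first, only, known or untested is meant among the compounds shown, and "the series" means these compounds.

Measured compounds:
Compound 1, `COc1cc(-c2nc3cc(/C=C4\SC(=O)NC4=O)ccc3[nH]2)cc(OC)c1OC`: in a functional assay on HeLa cells (Homo sapiens) for inhibition, read by MTT assay, with a stated time of 48 h (on this read-out higher numbers stand for weaker inhibition and lower numbers for stronger inhibition), compound 1 gives 1670 nM.
Compound 2, `COc1cc(OC)c(-c2nc3cc(/C=C4\SC(=O)NC4=O)ccc3[nH]2)cc1OC`: in this assay compound 2 gives 15400 nM.
Compound 3, `COc1cc(-c2nc3cc(/C=C4\SC(=O)NC4=O)ccc3[nH]2)ccc1OCC(C)C`: in this assay compound 3 gives 5220 nM.

Among these three, compound 1 shows the lowest number; the gap to compound 3 and the wider gap to compound 2 both lie beyond the usual scatter, so compound 1 counts as the most potent of the three. Compound 4, `COc1cc(-c2nc3cc(/C=C4\SC(=O)N(Cc5ccccc5)C4=O)ccc3[nH]2)cc(OC)c1OC`, has not been measured. It differs from compound 1 in one place: benzyl in place of hydrogen on an amide-type nitrogen in a ring, the rest of the shared core being kept. Among the compounds with values here, no step of this kind between measured compounds is available, so the expectation rests on compound 1 alone. The change is expected to cost some potency, with a step of a 2.1-fold higher number from compound 1 to compound 4 (0.32 log units; beyond the scatter) considered most likely. Compound 4 is therefore estimated at 3500 nM, within a range from 1000 nM to 12000 nM.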

Compound 4, half-maximal inhibitory concentration: 950 nM
Compound 4: the middle estimate sits 3.7-fold (0.57 log units) above what was measured; measured number outside the range, below it.
By their numbers in this assay, from the lowest: compounds 4 and 1 (each within the scatter of the next); then compound 3; then compound 2.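

Compounds 1, 2 and 3 all carry the amide hydrogen on this ring nitrogen, so they showed nothing about replacing it. In this assay, the step for benzyl in place of that hydrogen is a 1.8-fold lower number from compound 1 to compound 4 (0.24 log units; within the scatter), so this position takes benzyl with the two compounds indistinguishable in potency. Nothing available bears on the reason for this result.

The compounds shown leave open how methyl, a longer chain ending in an amine, or a carboxylic acid would fare on this nitrogen. They also leave open whether benzyl gives the same result on the cores of compound 2 and compound 3.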